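The source may hold more compounds than are shown below. What is called first, only, known or untested is meant among the compounds shown, and "the series" means these compounds.

Among the compounds with values here, compound 3 `N#Cc1cccc(/C(CCN2CCN(c3ccccn3)CC2)=N/O)c1` gives 13.1 nM in a functional assay on HEK293 cells with D(4) dopamine receptor (Homo sapiens) as the target, read by FLIPR (a higher number here means that more compound is needed for the effect, a lower number that less compound is needed), the highest of the three numbers measured so far. Compound 1 `O/N=C(\CCN1CCN(c2ccccn2)CC1)c1ccccc1` gives 4.4 nM, and compound 2 `Cc1cccc(/C(CCN2CCN(c3ccccn3)CC2)=N/O)c1` gives 2.3 nM. The two steps leading up to compound 3 were both modest: a 3.0-fold higher number from compound 1 to compound 3 (0.47 log units; beyond the scatter) and a 5.7-fold higher number from compound 2 to compound 3 (0.76 log units; beyond the scatter), whereas a 1.9-fold lower number from compound 1 to compound 2 (0.28 log units; within the scatter).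

Compound 4 `O/N=C(\CCN1CCN(c2ccccn2)CC1)c1ccc(Cl)cc1` differs from compound 3 in that (4-chlorophenyl in place of 3-cyanophenyl on a carbon with a double bond to nitrogen). Within the data shown here, no measured step introduces a chlorine, so what the chlorine itself adds is unknown. What does bear on the change is the removal of the cyano group, which was the feature that set compound 3 apart: taking it away reverses the direction of the steps that led from compound 1 and compound 2 to compound 3. A lower number, back toward the value of compound 1, is therefore expected, with the chlorine left as an open question. Compound 4 is expected to give 4.5 nM, with a range from 1.5 nM to 13 nM. This estimate corresponds to an expected step of a 2.9-fold lower number from compound 3 to compound 4 (0.46 log units; beyond the scatter).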

Compound 4, half-maximal effective concentration: 475 nM
Estimate against measurement, compound 4: 110-fold (2.02 log units) below, and the stated range ends below it.
By their numbers in this assay, from the lowest: compounds 2 and 1 (each within the scatter of the next); then compound 3; then compound 4.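

Within the data shown here, with a chlorine added to the phenyl group as the only difference, this is the first large step at this place in this assay: a 110-fold higher number from compound 1 to compound 4 (2.03 log units; beyond the scatter). The gap is as clear against the other two compounds, with a 36-fold higher number from compound 3 to compound 4 (1.56 log units; beyond the scatter) and a 210-fold higher number from compound 2 to compound 4 (2.31 log units; beyond the scatter). The phenyl group on this carbon therefore does not merely tolerate substitution: 3-methylphenyl and 3-cyanophenyl stay within a modest range of the unsubstituted compound 1, whereas 4-chlorophenyl falls far outside it.

Nothing shown accounts for the size of this step. Going by these compounds, whether the loss belongs to the chlorine or to where it sits remains open, and a 3-chlorophenyl or a 4-methylphenyl group at this place would separate the two.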